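Ester series on a shared core: aryl change at carbonyl

This account rests on a few compounds, and the source may have more. Where it says the series, first, only, none or still open, it means among the compounds named here.

Compound 1 `CC1=CC[C@H](C(C)C)c2cc(C)c(OC(=O)c3ccc([N+](=O)[O-])cc3)cc21` carries a 4-nitrophenyl group on the carbonyl carbon of its ester. Among the compounds with values here, in a functional assay on MCF7 cells (Homo sapiens) for antiproliferative activity, read by sulforhodamine B assay, with a stated time of 48 h, tested at 50 uM (a higher number here means more inhibition at the concentration tested (going by the name of the read-out), a lower number less inhibition), compound 1 gives 72.9%, the highest of the two numbers so far. Compound 2 `CC1=CC[C@H](C(C)C)c2cc(C)c(OC(=O)c3ccc(C(F)(F)F)cc3)cc21`, with trifluoromethyl in place of nitro on an aromatic carbon, gives 40.4% in this assay; the step of a number 32.5 percentage points lower from compound 1 to compound 2 (beyond the scatter) lies beyond the scatter.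

Compound 3 `CC1=CC[C@H](C(C)C)c2cc(C)c(OC(=O)c3cccc(C)c3)cc21` is the next member. The change from compound 1 is 3-methylphenyl in place of 4-nitrophenyl on a carbonyl carbon.

Within the data shown here, only one measured step bears on this move, and it is not the same change: it swaps one group for another on the same aromatic ring rather than replacing the whole 4-nitrophenyl by 3-methylphenyl. It does show that leaving the nitro arrangement of compound 1 cost a number 32.5 percentage points lower from compound 1 to compound 2 (beyond the scatter) in this assay. Among the measured compounds shown here, the move to 3-methylphenyl likewise leaves the nitro behind, so a drop of comparable size is expected, with wide uncertainty because no step for a methyl-bearing aryl is available.

The estimated step is a number 30.9 percentage points lower from compound 1 to compound 3 (beyond the scatter). For compound 3 in this assay the expected value is 42%, in the range 20% to 65%.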

Compound 3, a percentage reported as inhibition, at one concentration (the size of the read-out at that concentration, not a potency): 54.9%
Compound 3: the middle estimate sits 12.9 percentage points below what was measured, and the stated range covers the measured number.
By their numbers in this assay, from the lowest: compound 2; then compound 3; then compound 1.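

Replacing the whole aryl group at this carbonyl carbon gives a number 18 percentage points lower from compound 1 to compound 3 (beyond the scatter), so in this assay compound 1 stays the highest of the three, while 3-methylphenyl, an all-carbon group with no hydrogen-bond acceptors, still keeps a sizeable reading. The groups without nitro do not share one level: compound 2 gives 40.4% and compound 3 gives 54.9%, so losing the nitro does not fix the number at this position on its own. No measurement on hand explains the difference between these aryl groups.

The step from 4-nitrophenyl to 3-methylphenyl changes both the group and its place on the ring, and the compounds shown do not separate these two changes. Also open, as far as these compounds go, is how this position responds to an unsubstituted phenyl group, or to an aryl group carrying an amine or a carboxylic acid, and whether any such ester reaches the reading of compound 1.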